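Bromo Removal in a Cytotoxicity Series of Anilide Amides

The source may report more compounds than this note shows. Statements on the series, on what has been measured and on what is new or still open speak of the compounds shown alone.

Measured compounds in a functional assay on K562 cells (Homo sapiens) for cytotoxicity, read by XTT assay, with a stated time of 24 h; a lower number here means a stronger inhibitor, a higher number a weaker inhibitor:
compound 1, `Cc1ccc(NC(=O)c2ccc(Br)cc2OCCCCn2ccnc2)cc1Nc1nccc(-c2cccnc2)n1`, gives 66100 nM
compound 2, `Cc1ccc(NC(=O)c2ccccc2OCCCCn2ccnc2)cc1Nc1nccc(-c2cccnc2)n1`, gives 47500 nM
compound 3, `Cc1ccc(NC(=O)c2ccc(OCCCCn3ccnc3)c(Br)c2)cc1Nc1nccc(-c2cccnc2)n1`, gives 12000 nM

Compounds 1 and 2 share one core and differ only by hydrogen in place of bromo on an aromatic carbon. The step is a 1.4-fold lower number from compound 1 to compound 2 (0.14 log units; within the scatter), so the two values cannot be told apart here.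

Compound 3 is built from the same atoms as compound 1, joined differently; the difference between the two cores is not broken down here. Compound 3 gives the lowest number of the three, and its gaps to compound 2 and to compound 1 both lie beyond the usual scatter, so it is the strongest inhibitor among the measured compounds in this assay.

Compound 4, `Cc1ccc(NC(=O)c2ccc(OCCCCn3ccnc3)cc2)cc1Nc1nccc(-c2cccnc2)n1`, has not yet been measured. It differs from compound 3 by hydrogen in place of bromo on an aromatic carbon. This is the same kind of change as that from compound 1 to compound 2, but not the same: there the bromo sat meta to a 4-(1H-imidazol-1-yl)butoxy group and para to a large group, whereas here it sits ortho to a 4-(1H-imidazol-1-yl)butoxy group and meta to a large group.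

Resting on the earlier step, which was a 1.4-fold lower number from compound 1 to compound 2 (0.14 log units; within the scatter), compound 4 is expected to move by a 1.3-fold lower number from compound 3 to compound 4 (0.10 log units; within the scatter), a step that stays within the scatter. The estimate for compound 4 in this assay is 9500 nM, expected to fall between 4000 nM and 25000 nM.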

Compound 4, half-maximal inhibitory concentration: 49900 nM
Beside the measured number, compound 4's estimate is 5.3-fold (0.72 log units) below it; the whole stated range lies below it.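

In this assay, hydrogen in place of the bromo that sits ortho to a 4-(1H-imidazol-1-yl)butoxy group and meta to a large group gives a 4.2-fold higher number from compound 3 to compound 4 (0.62 log units; beyond the scatter), a modest step, whereas the same exchange on the core of compound 1 left the two values within the scatter. The change therefore did not carry over unchanged from one core to the other in this series: the same change on two cores in this assay, a 1.4-fold lower number (0.14 log units; within the scatter) from compound 1 to compound 2 and a 4.2-fold higher number (0.62 log units; beyond the scatter) from compound 3 to compound 4, 5.8-fold (0.76 log units) apart, beyond the scatter of two such steps. Among the compounds shown here, this rests on a single pair on each core in a single assay, and it shows only that the step on one core did not predict the step on the other; it does not show why the two differ, nor how the exchange would behave on any further core.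

The compounds shown leave open whether a chloro, fluoro or methoxy group in the place of the bromo on the core of compound 3 would give a number like that of compound 3 or like that of compound 4. They also leave open whether the gap between the two steps would persist with a shorter or longer chain in place of the 4-(1H-imidazol-1-yl)butoxy group.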